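The compounds below may be only part of what the source reports. "The series", "measured", "known", "first", "only" and "open" are said of these compounds alone.

Compound 1 `COc1ccc2c(=O)c(/C=C/C(=O)Nc3ccc(C)cc3)coc2c1` is the starting point of this step. In an ADME assay on HepG2 2.2.15 cells (Homo sapiens) for cytotoxicity, read by MTT assay, with stated times of 48 h and 9 days (on this read-out lower numbers stand for higher toxicity in this test and higher numbers for lower toxicity in this test), compound 1 gives 979000 nM, the highest of the three numbers recorded. Compound 2 `COc1ccc2c(=O)c(/C=C/C(=O)Nc3ccc(Cl)cc3)coc2c1` gives 272000 nM in this assay, and compound 3 `COc1ccc2c(=O)c(/C=C/C(=O)NCc3ccccc3)coc2c1` gives 376000 nM in this assay. Both departures from compound 1 lowered the number: a 3.6-fold lower number from compound 1 to compound 2 (0.56 log units; beyond the scatter), and a 2.6-fold lower number from compound 1 to compound 3 (0.42 log units; beyond the scatter). Between the two lower compounds there is a 1.4-fold higher number from compound 2 to compound 3 (0.14 log units; within the scatter).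

Compound 4 `COc1ccc2c(=O)c(/C=C/C(=O)Nc3cccc(C)c3)coc2c1` differs from compound 1 only in the arrangement of the same atoms: 3-methylphenyl in place of 4-methylphenyl on an amide-type nitrogen. Going by the values given here, no measured step moves the methyl around the ring while keeping it; the two steps from compound 1 each exchanged the whole group, one for a chloro-bearing ring and one for a benzyl, and each gave only a modest drop. A shift of the methyl alone is a smaller change than either, so no basis exists for expecting more than a modest drop, and a step within the scatter is the more likely outcome. The expected step in this assay is therefore a 1.4-fold lower number from compound 1 to compound 4 (0.15 log units; within the scatter), leaning slightly downward. Compound 4 is estimated at 700000 nM, with a range from 250000 nM to 2000000 nM.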

Compound 4, half-maximal cytotoxic concentration: 554000 nM
Compound 4: the middle estimate sits 1.3-fold (0.10 log units) above what was measured, and the stated range covers the measured number.
By their numbers in this assay, from the lowest: compounds 2, 3, 4 and 1 (each within the scatter of the next, the first and the last beyond it).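

With the methyl kept and only moved, 3-methylphenyl in place of 4-methylphenyl on the amide-type nitrogen gives a step that stays within the scatter in this assay (a 1.8-fold lower number from compound 1 to compound 4 (0.25 log units; within the scatter)), so these two methyl placements are not told apart here. The 3-methylphenyl compound also shows that the separation of the benzyl compound from compound 1 does not carry over to this isomer (a 1.5-fold higher number from compound 3 to compound 4 (0.17 log units; within the scatter)), whereas the 4-chlorophenyl compound stays separated from both methyl compounds, here by a modest margin only just past the scatter (a 2.0-fold higher number from compound 2 to compound 4 (0.31 log units; beyond the scatter)). Nothing available explains these numbers, and no cause can be given for them.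

On these data alone, whether a methoxy, an amine or a carboxylic acid on the same ring would stay in this narrow band in this assay remains open. As far as these compounds go, it is also open whether a longer chain on the amide-type nitrogen, such as phenethyl, would sit with the benzyl compound or move away from it.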